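Adding a Cyano Group Beside Bromine on a Weak Scaffold

The source may hold more compounds than are shown below. What is called first, only, known or untested is meant among the compounds shown, and "the series" means these compounds.

Of the compounds shown here, three built on one shared core have been tested in a functional assay on A-431 cells (Homo sapiens) for cytotoxicity, read by resazurin assay, with a stated time of 72 h; on this read-out lower numbers stand for stronger inhibition and higher numbers for weaker inhibition. Compound 1 `Cc1cc(OC(F)(F)F)ccc1/N=c1\ssnc1Cl` reaches only the assay limit, > 100000 nM. Compound 2 `FC(F)(F)Oc1ccc(/N=c2\ssnc2Cl)cc1Br` gives 100000 nM. Compound 3 `Clc1nss/c1=N\c1cccc(Br)c1` likewise stops at a limit, > 100000 nM. So compound 3 stands with the weakest readings shown, as the limit of > 100000 nM in this assay, at which 2 of the 3 values shown sit, makes clear. Among the measured compounds shown here, the single measured step, a number no lower from compound 2 to compound 3 (the limit leaves the size open), shows no readable change.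

Compound 4 `N#Cc1c(Br)cccc1/N=c1\ssnc1Cl` differs from compound 3 by cyano in place of hydrogen on an aromatic carbon. For the measured compounds named here, no measured step involves a cyano group, and every value so far sits at or near the limit, so no shift beyond the scatter is expected. Compound 4 is therefore estimated at 100000 nM, with a range from 30000 nM to 300000 nM. The expected step is a number no higher from compound 3 to compound 4 (the limit leaves the size open), essentially none.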

Compound 4, half-maximal inhibitory concentration: > 100000 nM
Compound 4 gave a limit, no number; the forecaster's own chance of this, stated with the estimate: 70%; the middle value lies on the limit itself.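

Among the compounds shown here, compound 3 and compound 4 both stop at a limit, so no step between them can be read: the limit of > 100000 nM in this assay, at which 3 of the 4 values shown sit.

The compounds shown leave open whether any change to the shared core gives clearly stronger cytotoxicity.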